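Ester and aryl variations in a thiourea series

The source may hold more compounds than are shown below. What is called first, only, known or untested is meant among the compounds shown, and "the series" means these compounds.

Measured so far:
compound 1 `CCCOC(=O)C1=C(C)NC(=S)NC1c1ccco1` — 46%
compound 2 `CC1=C(C(=O)OC(C)(C)C)C(c2ccco2)NC(=S)N1` — 9%
compound 3 `CCCOC(=O)C1=C(C)NC(=S)NC1c1cccs1` — 3%

In an assay on membranes from HEK293 cells for displacement of a labelled ligand from adenosine receptor A2b (Homo sapiens), read by scintillation counting, with a stated time of 30 min, tested at 1 uM (a lower number here means less inhibition, a higher number more inhibition at the concentration tested (going by the name of the read-out)), compound 1 gives 46%. The change tert-butyl in place of propyl on an oxygen next to a carbonyl group moved the read-out by a number 37 percentage points lower from compound 1 to compound 2 (beyond the scatter). The change thiophen-2-yl in place of furan-2-yl on a saturated ring carbon moved it by a number 43 percentage points lower from compound 1 to compound 3 (beyond the scatter). Compound 3 and compound 2 lie within the scatter of each other, so no order between them is claimed.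

Compound 4 `CC1=C(C(=O)OC(C)(C)C)C(c2cccs2)NC(=S)N1` is not yet measured. It differs from compound 3 by tert-butyl in place of propyl on an oxygen next to a carbonyl group, the same change as from compound 1 to compound 2; the two cores differ by thiophen-2-yl in place of furan-2-yl on a saturated ring carbon. Since compound 3 already gives 3% in this assay, there is little room for a further downward step of the earlier size, and the expected step is no change at the digits printed from compound 3 to compound 4 (within the scatter). Compound 4 is therefore estimated at 3%, with a likely range from -8% to 15% in this assay.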

Compound 4, a percentage reported as inhibition, at one concentration (the size of the read-out at that concentration, not a potency): 26%
Beside the measured number, compound 4's estimate is 23 percentage points below it; the whole stated range lies below it.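

In this assay, tert-butyl in place of propyl on an oxygen next to a carbonyl group gives a number 23 percentage points higher from compound 3 to compound 4 (beyond the scatter), which does not repeat the step seen with the furan-2-yl group: the same change on two cores in this assay, a number 37 percentage points lower (beyond the scatter) from compound 1 to compound 2 and a number 23 percentage points higher (beyond the scatter) from compound 3 to compound 4, 60 percentage points apart, beyond the scatter of two such steps. With tert-butyl in place of propyl, thiophen-2-yl in place of furan-2-yl on a saturated ring carbon gives a number 17 percentage points higher from compound 2 to compound 4 (beyond the scatter), which does not repeat the step seen with propyl: the same change on two cores in this assay, a number 43 percentage points lower (beyond the scatter) from compound 1 to compound 3 and a number 17 percentage points higher (beyond the scatter) from compound 2 to compound 4, 60 percentage points apart, beyond the scatter of two such steps. Going by these compounds alone, neither change can therefore be carried from one core to another as a fixed step, since the result of each depends on the other group, but these four compounds do not show why, and each change is read on only two cores.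

The compounds shown leave open whether this reversal extends to other groups on the oxygen, such as ethyl or isopropyl, or to a free carboxylic acid in place of the ester. They also leave open how a phenyl group on the saturated ring carbon, or a carbonyl in place of the thiocarbonyl, would behave with propyl and tert-butyl.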